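The compounds below may be only part of what the source reports. "The series", "measured", "known", "first", "only" and "open" are said of these compounds alone.

The compounds measured so far in an assay on HEK-293T cells for antagonist activity at vitamin D3 receptor (Homo sapiens), read by a luciferase reporter, with a stated time of 24 h; on this read-out higher numbers stand for weaker inhibition and lower numbers for stronger inhibition:
compound 1, `CC(C)c1onc(-c2c(Cl)cccc2Cl)c1COc1ccc(-c2nc3cc(C(=O)O)ccc3n2C)cc1`, gives 4410 nM;
compound 2, `CC(C)c1onc(-c2c(Cl)cccc2Cl)c1COc1ccc(-c2nc3ccc(C(=O)O)cc3n2CC(C)(C)C)cc1`, gives 861 nM;
compound 3, `CCC(CC)n1c(-c2ccc(OCc3c(-c4c(Cl)cccc4Cl)noc3C(C)C)cc2Cl)nc2ccc(C(=O)O)cc21`, gives 1010 nM.

Compound 2 has the lowest number of the three. Compound 3 lies within the usual scatter of it, so the two cannot be told apart on these data. Compound 1 stands beyond that scatter with a clearly higher number, so compound 2 inhibits more strongly than compound 1.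

Compound 4, `CC(C)c1onc(-c2c(Cl)cccc2Cl)c1COc1ccc(-c2nc3ccc(C(=O)O)cc3n2C2CCC2)cc1`, has not yet been measured. It differs from compound 2 in one place: cyclobutyl in place of neopentyl on an aromatic nitrogen. Both groups are built of carbon only, carry no hydrogen-bond donors or acceptors and no charge; the one that enters is a four-membered ring, the one that leaves has no ring.

Among the compounds with values here, no pair of measured compounds differs in only one place, so there is no direct measurement of how a change on this aromatic nitrogen moves the number. Given how alike the two groups are in what is counted, the step from compound 2 is expected to be small, in either direction or none beyond the scatter: a 1.2-fold higher number from compound 2 to compound 4 (0.06 log units; within the scatter).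

Compound 4 is therefore estimated at 1000 nM, with a range from 400 nM to 2500 nM.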

Compound 4, half-maximal inhibitory concentration: 1100 nM
For compound 4 the middle estimate is 1.1-fold (0.04 log units) below the measured one; the measured number falls inside the stated range.
By their numbers in this assay, from the lowest: compounds 2, 3 and 4 (each within the scatter of the next); then compound 1.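

In this assay, within the data shown here, the step of a 1.3-fold higher number from compound 2 to compound 4 (0.11 log units; within the scatter) comes from the first pair of compounds that differ only in the group on this aromatic nitrogen, with cyclobutyl in place of neopentyl. Among these compounds, compound 2 and compound 4 cannot be told apart here, even though the entering group has a four-membered ring and the leaving group has no ring, so at this position these two carbon-only groups give numbers within the usual scatter, something no earlier pair could show as each differed in more than one place. No measurement offered here explains this result.

Because cyclobutyl and neopentyl are both built of carbon only, the compounds shown leave open what a group containing oxygen, such as a methoxyethyl chain, would do on this aromatic nitrogen. They also leave open whether a larger ring such as cyclohexyl would stay within the scatter of compound 4 or move clearly away from it.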